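From allyl to propargyl on the amide nitrogen

This account rests on a few compounds, and the source may have more. Where it says the series, first, only, none or still open, it means among the compounds named here.

Compound 1 `C/C(C(=O)NC1CC1)=C(/C)c1ccc(Cl)cc1` gives 11.4 mg/kg in a functional assay on the whole organism with Mus musculus as the target; on this read-out higher numbers stand for an effect only at larger amounts of compound and lower numbers for an effect already at smaller amounts. Compound 2 `C=CCNC(=O)/C(C)=C(\C)c1ccc(Cl)cc1` gives 18.6 mg/kg, the higher of the two numbers shown, although the step of a 1.6-fold higher number from compound 1 to compound 2 (0.21 log units; within the scatter) lies within the scatter. Compound 3 `C#CCNC(=O)/C(C)=C(\C)c1ccc(Cl)cc1` differs from compound 2 by ethynyl in place of vinyl on a saturated chain carbon bound to an amide-type nitrogen. For the measured compounds named here, no measured step covers this exact exchange; the one step at hand, a 1.6-fold higher number from compound 1 to compound 2 (0.21 log units; within the scatter), shows that exchanging the group on the amide-type nitrogen left the number within the scatter, so the expected step of a 1.0-fold lower number from compound 2 to compound 3 (0.01 log units; within the scatter) is none beyond the scatter. Compound 3 is therefore estimated at 18 mg/kg, between 9 mg/kg and 36 mg/kg.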

Compound 3, dose for half-maximal effect: 10.6 mg/kg
The estimate for compound 3 lay 1.7-fold (0.23 log units) above the measured number; low and high end bracket the measured number.
By their numbers in this assay, from the lowest: compounds 3, 1 and 2 (each within the scatter of the next).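

In this assay the exchange of vinyl for ethynyl gives a 1.8-fold lower number from compound 2 to compound 3 (0.24 log units; within the scatter) and the exchange of cyclopropyl for propargyl gives a 1.1-fold lower number from compound 1 to compound 3 (0.03 log units; within the scatter) on the same read-out. Allyl, cyclopropyl and propargyl on the amide-type nitrogen thus all lie within the scatter of one another, and no step at this position goes beyond it. Nothing at hand explains this result. From the compounds shown here alone, whether a longer chain, a benzyl group or a chain carrying an amine on that nitrogen would move the number beyond the scatter stays open.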